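Amide substituent swap: cyclopentyl to oxan-4-yl

A few compounds are considered here, and "the series" means these few. Any claim that something is new, unique, unknown or untested is made for them only; others in the source may bear on it.

Two compounds in the series have numbers in an assay on CHO-K1 cells for displacement of a labelled ligand from prostaglandin E2 receptor EP1 subtype (Homo sapiens); on this read-out lower numbers stand for stronger inhibition and higher numbers for weaker inhibition. Compound 1 `Cc1cc(C(=O)Nc2c(F)cccc2F)nn1Cc1cc(Cl)ccc1OCc1ccccc1` gives 10 nM. Going by the values given here, compound 2 `Cc1cc(NC(=O)C2CCCC2)nn1Cc1cc(Cl)ccc1OCc1ccccc1` gives 15.9 nM, the higher of the two numbers, with compound 1 as its only neighbour; the separation a 1.6-fold higher number from compound 1 to compound 2 (0.20 log units; within the scatter) lies within the scatter, so no order between the two is claimed. Compound 3 `Cc1cc(NC(=O)C2CCOCC2)nn1Cc1cc(Cl)ccc1OCc1ccccc1` is not yet measured. It differs from compound 2 as follows: oxan-4-yl in place of cyclopentyl on a carbonyl carbon.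

Among the compounds with values here, only one measured step exists, and it changes the same region: from compound 1 to compound 2 the whole (2,6-difluorophenyl)carbamoyl arrangement on the aromatic carbon was exchanged for (cyclopentylcarbonyl)amino, and the result was a 1.6-fold higher number from compound 1 to compound 2 (0.20 log units; within the scatter), within the scatter. That step indicates that a change of the group on the carbonyl carbon need not move the number much; there is no measured ring-to-ring exchange of this exact kind to lean on. For compound 3 the expected step is therefore a 1.4-fold higher number from compound 2 to compound 3 (0.14 log units; within the scatter), a small shift towards a higher number that stays within the usual scatter. The estimate for compound 3 in this assay is 22 nM, with an expected range from 8 nM to 65 nM.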

Compound 3, half-maximal inhibitory concentration: 63.1 nM
Estimate against measurement, compound 3: 2.9-fold (0.46 log units) below, and the stated range covers the measured number.
By their numbers in this assay, from the lowest: compounds 1 and 2 (each within the scatter of the next); then compound 3.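

Going by these compounds alone, on the carbonyl carbon next to the amide-type nitrogen, the ring is not a neutral choice in this assay: oxan-4-yl in place of cyclopentyl gives a 4.0-fold higher number from compound 2 to compound 3 (0.60 log units; beyond the scatter), a modest step beyond the scatter, whereas the one step known before it, a 1.6-fold higher number from compound 1 to compound 2 (0.20 log units; within the scatter), stayed within the scatter. The exchange of (2,6-difluorophenyl)carbamoyl for ((oxan-4-yl)carbonyl)amino on the aromatic carbon reads a 6.3-fold higher number from compound 1 to compound 3 (0.80 log units; beyond the scatter), so compound 3 is set apart from both neighbours and has the highest number of the three. The change swaps a five-membered carbon-only ring for a six-membered ring with one hetero atom and one hydrogen-bond acceptor, and no supporting measurement bears on why the number rises.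

Ring size and the ring oxygen change together in this step, so the compounds shown cannot assign the rise to either one; cyclohexyl on the same carbonyl carbon would separate the two. On these data alone, how a ring amine such as piperidin-4-yl, or an open chain such as a longer alkyl group, would read at this position also stays open.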